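A few compounds are considered here, and "the series" means these few. Any claim that something is new, unique, unknown or untested is made for them only; others in the source may bear on it.

Compound 1 `O=C(Nc1ccc(Cl)c(-c2nnc3c(Cl)cccn23)c1)c1ccc(F)cc1Cl`: 75000 nM
Compound 2 `O=C(Nc1ccc(Cl)c(-c2nnc3c(Cl)cccn23)c1)c1c(F)cccc1Cl`: > 100000 nM

In a functional assay on MDA-MB-231 cells (Homo sapiens) for antiproliferative activity, read by MTT assay, with stated times of 72 h and 4 h (a lower number here means a stronger inhibitor, a higher number a weaker inhibitor), compound 1 gives 75000 nM. Compound 2 gives no number in this assay but only a limit, > 100000 nM, which is the limit of > 100000 nM in this assay, at which 1 of the 2 values shown sits. Compound 2 thus stands at the point where this assay stops reporting a value.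

The move to compound 3 `O=C(Nc1ccc(Cl)c(-c2nnc3c(Cl)cccn23)c1)c1ccccc1` is phenyl in place of 2-chloro-6-fluorophenyl on a carbonyl carbon. Going by the values given here, one measured step touches the ring on the carbonyl carbon: an at least 1.3-fold higher number from compound 1 to compound 2 (0.12 log units; that floor lies within the scatter), a rearrangement of the halogens on that ring, with a floor that lies within the scatter. No measured step strips both halogens from that ring, so the change to phenyl has no direct precedent among the compounds shown. With both measured values at or close to the limit, no shift beyond the scatter is expected in this assay. Compound 3 is accordingly estimated at about 100000 nM (40000 nM to 300000 nM), an expected step of a number no higher from compound 2 to compound 3 (the limit leaves the size open).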

Compound 3, half-maximal inhibitory concentration: 58200 nM
Compound 3: middle estimate off by 1.7-fold (0.24 log units), on the high side, and the stated range covers the measured number.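

Phenyl in place of 2-chloro-4-fluorophenyl gives a 1.3-fold lower number from compound 1 to compound 3 (0.11 log units; within the scatter) in this assay, so the two halogens of compound 1 make no readable difference at this place. Phenyl in place of 2-chloro-6-fluorophenyl gives an at least 1.7-fold lower number from compound 2 to compound 3 (0.23 log units; that floor lies within the scatter), which leaves the size of that step open. Compound 2 has a limit here, not a number: the limit of > 100000 nM in this assay, at which 1 of the 3 values shown sits.

On these data alone, all three compounds carry a six-membered aromatic ring of carbon only on the carbonyl carbon, so the effect of an amine, a carboxylic acid or a longer alkyl chain at this place stays open. Also open, as far as these compounds go, is what a single chlorine or a single fluorine on the phenyl would do, and whether any change here can move the number beyond the scatter.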